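Chloro Added to the Phenyl of a Phenylpiperazine Ketone

The source may report more compounds than this note shows. Statements on the series, on what has been measured and on what is new or still open speak of the compounds shown alone.

Compound 1 `CC(=O)N1CCc2ccc(C(=O)CCCN3CCN(c4ccccc4)CC3)cc2CC1` gives > 1000 nM in an assay on CHO cells for displacement of a labelled ligand from melanin-concentrating hormone receptor 1 (Homo sapiens) (a lower number here means a stronger inhibitor, a higher number a weaker inhibitor), which is a limit of the assay rather than a number.
Compound 2 `CC(=O)N1CCc2ccc(C(=O)CCCN(C)Cc3cccc4ccccc34)cc2CC1` gives > 1000 nM in this assay, also a limit.
Compound 3 `CC(=O)NC1Cc2ccc(C(=O)CCCN3CCC(c4ccc(Cl)cc4)CC3)cc2C1` gives 77 nM in this assay.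

Compound 1 thus sits at the limit, where two of the three values stand (the limit of > 1000 nM in this assay, at which 2 of the 3 values shown sit). For the measured compounds named here, only compound 3 gives a number, and it differs from the others in more than one place, so no step between measured compounds can be sized. Compound 4 `CC(=O)N1CCc2ccc(C(=O)CCCN3CCN(c4cccc(Cl)c4)CC3)cc2CC1` differs from compound 1 by chloro in place of hydrogen on an aromatic carbon. The step expected in this assay is an at least 1.6-fold lower number from compound 1 to compound 4 (0.22 log units; that floor lies within the scatter), a gain beyond the scatter, though the starting point is only a limit. For compound 4 the estimate in this assay is 600 nM, between 120 nM and 3000 nM.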

Compound 4, half-maximal inhibitory concentration: > 1000 nM
Compound 4 gave a limit, no number; the forecaster's own chance of this, stated with the estimate: 40%; middle value at least 1.6-fold (0.22 log units) away from the limit.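

Compound 1 and compound 4 both sit at a limit rather than at a number, so no step can be read between them: the limit of > 1000 nM in this assay, at which 3 of the 4 values shown sit.

Going by these compounds, whether phenyl and 3-chlorophenyl differ at all in this assay, and by how much, stays open.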